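The source may hold more compounds than are shown below. What is called first, only, known or untested is meant among the compounds shown, and "the series" means these compounds.

Working notes on the series. Compound 1 `CCc1nc(N)nc2c1c(-c1ccc3oc(N)nc3c1)nn2C(C)C` is the reference point here. In an ADME assay on microsomes from liver (Homo sapiens) for metabolic stability, read by LC-MS, with a stated time of 15 min, tested at 1 uM, in the presence of a further agent that is not named here (a higher number here means that more of the compound is left, a lower number that less of the compound is left), compound 1 gives 93%, the highest of the three numbers recorded so far, though neither of the other two sits beyond the scatter of it. Its nearest neighbour is compound 2 `CC(C)n1nc(-c2ccc3oc(N)nc3c2)c2c(Cl)nc(N)nc21`, which in this assay gives 92%; the step of a number 1 percentage points lower from compound 1 to compound 2 (within the scatter). The furthest is compound 3 `CC(C)n1nc(-c2ccc3oc(N)nc3c2)c2c(F)nc(N)nc21`, which in this assay gives 83%; the step of a number 10 percentage points lower from compound 1 to compound 3 (within the scatter). Between the two halogen analogues the step of a number 9 percentage points lower from compound 2 to compound 3 (within the scatter).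

The next compound is compound 4 `CC(C)n1nc(-c2ccc3oc(N)nc3c2)c2c(C#N)nc(N)nc21`. Relative to compound 1 the change is cyano in place of ethyl on an aromatic carbon. The three measured steps all concern exchanges at this same aromatic carbon, and every one of them stayed within the scatter, so the shared core appears to tolerate ethyl, chloro and fluoro there with little movement in the percent remaining. On that basis the step to compound 4 is expected to be a number 5 percentage points lower from compound 1 to compound 4 (within the scatter), which is to say no step beyond the scatter in either direction. For compound 4 in this assay the estimate is therefore 88%, with a range from 75% to 97%.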

Compound 4, percent of the compound remaining: > 95%
Compound 4: a limit, no number; the forecaster's own chance of this, stated with the estimate: 5%; middle value at least 7 percentage points away from the limit.
By their numbers in this assay, from the lowest: compounds 3, 2 and 1 (each within the scatter of the next). At a limit, above all of these: compound 4.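

In this assay compound 4 gives > 95%, which is a limit of the assay and not a number. Going by these compounds alone, the cyano group, in place of fluoro on this aromatic carbon, gives the first step that clears the scatter: a number at least 12 percentage points higher from compound 3 to compound 4 (beyond the scatter). Against the other two groups the result is less decisive, with a number at least 2 percentage points higher from compound 1 to compound 4 (that floor lies within the scatter) and a number at least 3 percentage points higher from compound 2 to compound 4 (that floor lies within the scatter), so the position accepts cyano without any loss in the percent of compound remaining, but a real gain over ethyl or chloro is not established.

From the compounds shown here alone, with only a floor for compound 4, its true distance from compound 1 and compound 2 stays open, and so does whether the percent remaining at this position has any dependence on the group beyond the contrast between cyano and fluoro. Also open, going by these compounds, is how an amine, a carboxylic acid, a methoxy group or a longer chain on this aromatic carbon would read in this assay, and what a change anywhere else on the shared core would do, since all four compounds differ at this one place only.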